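Swapping the Aryl Amine Group: Compound 4 Expected Near Its Peers

This account rests on a few compounds, and the source may have more. Where it says the series, first, only, none or still open, it means among the compounds named here.

Three compounds share one core and differ only in the group attached to a nitrogen on an aromatic ring. In a functional assay on A-431 cells (Homo sapiens) for antiproliferative activity, read by MTT assay, with a stated time of 72 h (on this read-out lower numbers stand for stronger inhibition and higher numbers for weaker inhibition), compound 1 `C#Cc1cccc(Nc2ncnc3ccc(NC(=S)Nc4ccc(S(N)(=O)=O)cc4)cc23)c1` gives 15300 nM. Compound 2 `NS(=O)(=O)c1ccc(NC(=S)Nc2ccc3ncnc(Nc4ccc(Cl)c(C(F)(F)F)c4)c3c2)cc1` gives 18200 nM in this assay, and compound 3 `NS(=O)(=O)c1ccc(NC(=S)Nc2ccc3ncnc(Nc4cccc(Cl)c4F)c3c2)cc1` gives 13100 nM. Compound 3 carries the lowest of the three numbers, yet the gaps between them are small: a 1.2-fold lower number from compound 1 to compound 3 (0.07 log units; within the scatter) and a 1.4-fold lower number from compound 2 to compound 3 (0.14 log units; within the scatter), and likewise a 1.2-fold higher number from compound 1 to compound 2 (0.08 log units; within the scatter). On these numbers the three compounds cannot be told apart.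

Compound 4 `NS(=O)(=O)c1ccc(NC(=S)Nc2ccc3ncnc(Nc4cccc(F)c4)c3c2)cc1` has not yet been measured. It differs from compound 3 in a single place: 3-fluorophenyl in place of 3-chloro-2-fluorophenyl on a nitrogen on an aromatic ring. Within the data shown here, the only evidence that bears on this change is the set of three earlier swaps of the same group, each of which left the number essentially where it was. Nothing in those steps points to a move in either direction, so no step beyond the scatter is expected, and the expected change is a 1.1-fold higher number from compound 3 to compound 4 (0.06 log units; within the scatter). Compound 4 is therefore estimated at 15000 nM in this assay. The expected range for compound 4 runs from 6000 nM to 40000 nM.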

Compound 4, half-maximal inhibitory concentration: 30100 nM
For compound 4 the middle estimate is 2.0-fold (0.30 log units) below the measured one, and the stated range covers the measured number.
By their numbers in this assay, from the lowest: compounds 3, 1, 2 and 4 (each within the scatter of the next, the first and the last beyond it).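

Among these compounds, of the swaps at this place, on a nitrogen on an aromatic ring, the change from 3-chloro-2-fluorophenyl to 3-fluorophenyl is the first to carry the number beyond the scatter in this assay, with a 2.3-fold higher number from compound 3 to compound 4 (0.36 log units; beyond the scatter) as a modest step. Among the compounds shown here, that step is the only one involving compound 4 to do so, since a 1.7-fold higher number from compound 2 to compound 4 (0.22 log units; within the scatter) and a 2.0-fold higher number from compound 1 to compound 4 (0.29 log units; within the scatter) both remain within the scatter, which means that compound 4 separates from compound 3 but cannot be told apart from compound 1 or compound 2 on these numbers. The group at this place can therefore shift the read-out a little, though the data shown give no measured explanation for the step.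

The change from compound 3 to compound 4 removes the chlorine and also changes the numbered position of the fluorine, so this single pair cannot show which of the two alterations matters, or whether both do. A 3-chlorophenyl or a plain phenyl group on the same nitrogen would help pull those two alterations apart, while a group such as a pyridine ring or a longer alkyl chain would test whether the aromatic carbon ring is needed at all.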